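Phenyl for methyl on the core of compound 1

The source may hold more compounds than are shown below. What is called first, only, known or untested is meant among the compounds shown, and "the series" means these compounds.

Compound 1 `Cc1nc2ccccc2c(=O)n1/N=C/c1ccc(Oc2ccc(Br)cc2)cc1` sits second highest of the three numbers measured in a physicochemical assay for lipophilicity, in phosphate buffer, measured as octanol-water partition (on this read-out higher numbers stand for higher lipophilicity and lower numbers for lower lipophilicity), where compound 1 gives 4.64. Compound 2 `Cc1nc2ccccc2c(=O)n1/N=C/c1ccc(Oc2ccc(Cl)cc2)cc1` is nearest, giving 4.6 in this assay, and the step of a number 0.04 log units lower from compound 1 to compound 2 (within the scatter). Compound 3 `Cc1nc2ccccc2c(=O)n1/N=C/c1ccc(Oc2ccc3ccccc3c2)cc1` lies furthest, giving 5.22 in this assay.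

The step to compound 4 `O=c1c2ccccc2nc(-c2ccccc2)n1/N=C/c1ccc(Oc2ccc(Br)cc2)cc1` is phenyl in place of methyl on an aromatic carbon. Among the compounds with values here, no measured pair alters this position; the two steps that bear on it are those that enlarge an aromatic part elsewhere in the molecule: a number 0.58 log units higher from compound 1 to compound 3 (beyond the scatter) and a number 0.62 log units higher from compound 2 to compound 3 (beyond the scatter). Both steps add aromatic carbon only and both move this assay upward by a modest amount. Exchanging methyl for phenyl adds more aromatic carbon than either of those steps, so an upward step beyond the scatter is expected for compound 4 in this assay, likely somewhat larger than the step from compound 1 to compound 3.

For compound 4 the estimate in this assay is 5.7, with a range from 5.2 to 6.3, which corresponds to an expected step of a number 1.06 log units higher from compound 1 to compound 4 (beyond the scatter).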

Compound 4, partition coefficient: 6.39
Beside the measured number, compound 4's estimate is 0.69 log units below it, outside the stated range (above it).
By their numbers in this assay, from the lowest: compounds 2 and 1 (each within the scatter of the next); then compound 3; then compound 4.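

On the aromatic carbon between two ring nitrogen atoms of the shared core, phenyl in place of methyl gives a number 1.75 log units higher from compound 1 to compound 4 (beyond the scatter) in this assay and is the only step shown at this position. Within the data shown here, it is larger than a number 0.58 log units higher from compound 1 to compound 3 (beyond the scatter) where naphthalen-2-yl replaces 4-bromophenyl on an oxygen on an aromatic ring, so this position on the core, which the earlier compounds left untouched, carries the largest step so far. Nothing on hand accounts for the size of this step.

The compounds shown leave open how the number in this assay moves across groups of intermediate size at this position, such as an ethyl or a cyclohexyl group, and whether a phenyl bearing an amine or a carboxylic acid would stay near the level of compound 4. They also leave open whether phenyl in place of methyl gives a step of similar size when chloro stands in place of bromo or naphthalen-2-yl in place of 4-bromophenyl elsewhere in the molecule.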